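The source may report more compounds than this note shows. Statements on the series, on what has been measured and on what is new or still open speak of the compounds shown alone.

Values in an ADME assay on 2209-23 cells (Homo sapiens) for cytotoxicity, read by WST assay and thymidine incorporation (a lower number here means that less compound is tolerated, a higher number that more compound is tolerated), each one a limit of the assay:
Compound 1 `CC(C)(C)[C@H]1C(O)=C(C2=C(Cl)S(=O)(=O)c3cc(NS(C)(=O)=O)ccc3N2)C(=O)N1Cc1ccc(F)cc1`: > 50000 nM
Compound 2 `CC(C)(C)[C@H]1C(O)=C(C2=CS(=O)(=O)c3cc(NS(C)(=O)=O)ccc3N2)C(=O)N1Cc1ccc(F)cc1F`: > 50000 nM
Compound 3 `CC(C)(C)[C@H]1C(O)=C(C2=C(C#N)S(=O)(=O)c3cc(NS(C)(=O)=O)ccc3N2)C(=O)N1Cc1ccc(F)cc1`: > 50000 nM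

Compound 2 gives no number, only the limit > 50000 nM. It shares this position with the other two compounds, as the limit of > 50000 nM in this assay, at which 3 of the 3 values shown sit, shows.

Compound 4 `CC(C)CCN1C(=O)C(C2=CS(=O)(=O)c3cc(NS(C)(=O)=O)ccc3N2)=C(O)[C@@H]1C(C)(C)C` departs from compound 2 by one change: isobutyl in place of 2,4-difluorophenyl on a saturated chain carbon bound to an amide-type nitrogen in a ring. Within the data shown here, the only measured step is a step that the two limits leave unreadable from compound 1 to compound 3. It lies at a different place and gives no size for this change. No step beyond the scatter is therefore expected in this assay, in either direction.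

The expected step is a number no higher from compound 2 to compound 4 (the limit leaves the size open).

For compound 4 the estimated value is 50000 nM, with an expected range of 25000 nM to 100000 nM.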

Compound 4, half-maximal cytotoxic concentration: > 50000 nM
Compound 4: only a limit was reported; the forecaster's own chance of this, stated with the estimate: 85%; the middle value sits exactly at the limit.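

In this assay, among these compounds, compound 4 gives > 50000 nM, which is a limit of the assay, so no step from compound 2 to compound 4 can be read. The compounds shown leave open what concentration any of them would need to reach the half-maximal cytotoxic read-out.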